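A few compounds are considered here, and "the series" means these few. Any claim that something is new, unique, unknown or untested is made for them only; others in the source may bear on it.

Compound 1 `O=C(Nc1cccc(-c2ccccc2C(F)(F)F)c1)C(Cl)Cl`: 7500 nM
Compound 2 `O=C(Nc1cccc(-c2ccc(-c3ccccc3)cc2)c1)C(Cl)Cl`: > 50000 nM

In a functional assay on A549 cells (Homo sapiens) for cytotoxicity, read by MTT assay, with a stated time of 68 h (a lower number here means a stronger inhibitor, a higher number a weaker inhibitor), compound 2 gives > 50000 nM, which is a limit of the assay and not a number. the limit of > 50000 nM in this assay, at which 1 of the 2 values shown sits, marks where it stands.

Compound 3 `O=C(Nc1cccc(-c2ccc(F)cc2)c1)C(Cl)Cl` has fluoro in place of phenyl on an aromatic carbon, para to a large group: fluoro in place of phenyl on an aromatic carbon. Among the measured compounds shown here, no measured step shows what this change does, so the only numerical guide is compound 1 at 7500 nM. A moderate move toward stronger inhibition is expected in this assay, with an estimated at least 3.3-fold lower number from compound 2 to compound 3 (0.52 log units; beyond the scatter). Compound 3 is expected at about 15000 nM, within an estimated range of 5000 nM to 45000 nM.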

Compound 3, half-maximal inhibitory concentration: 7840 nM
For compound 3 the middle estimate is 1.9-fold (0.28 log units) above the measured one; the measured number falls inside the stated range.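

In this assay, putting fluoro in place of phenyl on this aromatic carbon gives an at least 6.3-fold lower number from compound 2 to compound 3 (0.80 log units; beyond the scatter). Among the compounds shown here, this shows that the group at this position matters for the reading, which the earlier compounds could not show. The full size of the step stays unknown, because compound 2 carries a limit of the assay and not a number: the limit of > 50000 nM in this assay, at which 1 of the 3 values shown sits.

Two groups at one position do not make a trend. As far as these compounds go, how an amine or a carboxylic acid on this same carbon would compare remains open.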